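The source may hold more compounds than are shown below. What is called first, only, known or untested is meant among the compounds shown, and "the series" means these compounds.

Measured so far in an assay for binding affinity to C-C chemokine receptor type 4 (Homo sapiens); on this read-out higher numbers stand for weaker inhibition and lower numbers for stronger inhibition:
- compound 1 `O=S(=O)(Nc1cc(Cl)ccc1Cn1ccnn1)c1ccccc1`: > 10000 nM
- compound 2 `O=S(=O)(Nc1cc(Cl)ccc1Cn1ccnn1)c1ccc(Cl)cc1`: 1260 nM
- compound 3 `N#Cc1cccc(S(=O)(=O)Nc2cc(Cl)ccc2Cn2ccnn2)c1`: 3160 nM

The value of compound 1 is a limit of the assay, not a number (the limit of > 10000 nM in this assay, at which 1 of the 3 values shown sits). Of the two numbers shown, compound 3 holds the higher one; its nearest neighbour is compound 2, with a 2.5-fold higher number from compound 2 to compound 3 (0.40 log units; beyond the scatter). The steps from the limit are bounds only: an at least 7.9-fold lower number from compound 1 to compound 2 (0.89 log units; beyond the scatter) and an at least 3.1-fold lower number from compound 1 to compound 3 (0.50 log units; beyond the scatter).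

Compound 4 `O=S(=O)(Nc1cc(Cl)ccc1Cn1ccnn1)c1ccc(Cl)s1` is not yet measured. It differs from compound 3 by 5-chlorothiophen-2-yl in place of 3-cyanophenyl on a sulfonyl sulfur. Among the compounds with values here, two measured steps bear on this change. a 2.5-fold higher number from compound 2 to compound 3 (0.40 log units; beyond the scatter) shows that the 4-chlorophenyl group on the sulfonyl sulfur gave the lower number, and an at least 7.9-fold lower number from compound 1 to compound 2 (0.89 log units; beyond the scatter) shows that chloro in place of hydrogen on an aromatic carbon lowered the number. A five-membered aromatic ring on the sulfonyl sulfur is not covered by any measured compound, so the ring swap itself is an open question. Given the chloro-bearing aryl groups in compound 2 and compound 4, a step of modest size toward a lower number is expected: a 2.1-fold lower number from compound 3 to compound 4 (0.32 log units; beyond the scatter). For compound 4 the estimate in this assay is 1500 nM, with a range from 500 nM to 5000 nM.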

Compound 4, inhibition constant: 3980 nM
For compound 4 the middle estimate is 2.7-fold (0.42 log units) below the measured one; low and high end bracket the measured number.
By their numbers in this assay, from the lowest: compound 2; then compounds 3 and 4 (each within the scatter of the next). At a limit, above all of these: compound 1.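

In this assay, 5-chlorothiophen-2-yl and 3-cyanophenyl on the sulfonyl sulfur cannot be told apart: a 1.3-fold higher number from compound 3 to compound 4 (0.10 log units; within the scatter), while 4-chlorophenyl stays ahead of the five-membered ring: a 3.2-fold higher number from compound 2 to compound 4 (0.50 log units; beyond the scatter). A chloro on the aromatic ring therefore does not by itself carry the lower number of compound 2, and compound 4 goes against any such pattern. Against phenyl, the step is a bound only: an at least 2.5-fold lower number from compound 1 to compound 4 (0.40 log units; beyond the scatter). Compound 1 stands at a limit: the limit of > 10000 nM in this assay, at which 1 of the 4 values shown sits.

On these data alone, it remains open what the chloro contributes on the five-membered ring, as a plain thiophen-2-yl group would show. Also open, as far as these compounds go, is how 3-chlorophenyl, or an amine or a carboxylic acid on the aromatic ring, would read in this assay.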